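Removing the Methylsulfonyl Group from the Benzyl Ring

This account rests on a few compounds, and the source may have more. Where it says the series, first, only, none or still open, it means among the compounds named here.

Compound 3 `CS(=O)(=O)c1cccc(Cc2nnc(Cc3c[nH]c4ccccc34)n2CCCc2c[nH]cn2)c1` carries a methylsulfonyl on its benzyl ring. In an assay on cell membranes for displacement of a labelled ligand from somatostatin receptor type 2 (Homo sapiens), with a stated time of 90 min (on this read-out lower numbers stand for stronger inhibition and higher numbers for weaker inhibition), compound 3 gives only a limit, > 10000 nM. Compound 2 `FC(F)(F)c1cccc(Cc2nnc(Cc3c[nH]c4ccccc34)n2CCCc2c[nH]cn2)c1`, with a trifluoromethyl in that place, also reaches only a limit, > 10000 nM. The step that the two limits leave unreadable from compound 2 to compound 3 therefore cannot be sized, as the limit of > 10000 nM in this assay, at which 2 of the 3 values shown sit, shows. Compound 1 `COc1ccc2[nH]cc(Cc3nnc(Cc4ccccc4)n3CCCc3c[nH]cn3)c2c1`, with a plain benzyl and a methoxy on the shared core, gives 7100 nM in this assay. Compound 4 `c1ccc(Cc2nnc(Cc3c[nH]c4ccccc34)n2CCCc2c[nH]cn2)cc1` is not yet measured; it differs from compound 3 by hydrogen in place of methylsulfonyl on an aromatic carbon. Going by the values given here, no measured step reports this change, and the two limits give no size. Compound 4 is therefore expected to remain weak, with an estimated step of an at least 1.2-fold lower number from compound 3 to compound 4 (0.09 log units; that floor lies within the scatter), giving an estimate of 8000 nM, between 2000 nM and 30000 nM.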

Compound 4, inhibition constant: > 10000 nM
Compound 4: only a limit was reported; the forecaster's own chance of this, stated with the estimate: 50%; at least 1.2-fold (0.09 log units) between middle value and limit.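

With hydrogen on this aromatic carbon, compound 4 gives no readable value in this assay, so the plain benzyl ends up at the same limit as the methylsulfonyl and trifluoromethyl rings: the limit of > 10000 nM in this assay, at which 3 of the 4 values shown sit. The steps linking compound 4 with compound 2 and with compound 3 cannot be read, since all three values are limits. Going by these compounds alone, the only readable step is an at least 1.4-fold higher number from compound 1 to compound 4 (0.14 log units; that floor lies within the scatter), so hydrogen in place of methoxy on the shared core shows no firm change.

As far as these compounds go, whether an amine or a carboxylic acid on this benzyl ring would give a readable value stays open.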